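Sulfonyl group exchange from compound 3 to compound 4

The source may report more compounds than this note shows. Statements on the series, on what has been measured and on what is new or still open speak of the compounds shown alone.

In a functional assay on K562 cells (Homo sapiens) for inhibition, read by trypan blue exclusion, with a stated time of 72 h (on this read-out lower numbers stand for stronger inhibition and higher numbers for weaker inhibition), compound 3 `Cn1c(=O)c(S(=O)(=O)Cc2ccc(F)cc2F)cc2cnc(Nc3ccc4[nH]ccc4c3)nc21` gives 1000 nM and stands level with compound 1 `Cn1c(=O)c(S(=O)(=O)c2ccc(Cl)cc2Cl)cc2cnc(Nc3ccc4[nH]ccc4c3)nc21` at 1000 nM as the lowest of three numbers. Compound 2 `Cn1c(=O)c(S(=O)(=O)c2ccc(C(=O)O)cc2)cc2cnc(Nc3ccc4[nH]ccc4c3)nc21` gives 5000 nM on the same read-out. Compound 4 `COc1ccc(S(=O)(=O)c2cc3cnc(Nc4ccc5[nH]ccc5c4)nc3n(C)c2=O)cc1` carries 4-methoxyphenyl in place of 2,4-difluorobenzyl on a sulfonyl sulfur. For the measured compounds named here, two measured steps bear on this. Exchanging 2,4-dichlorophenyl for 2,4-difluorobenzyl gave no change at the digits printed from compound 1 to compound 3 (within the scatter) while exchanging it for 4-carboxyphenyl gave a 5.0-fold higher number from compound 1 to compound 2 (0.70 log units; beyond the scatter) as the only modest shift seen. With a neutral-counted group entering, the expected outcome in this assay is no change at the digits printed from compound 3 to compound 4 (within the scatter) with no shift beyond the scatter. Compound 4 is estimated at 1000 nM within an expected range of 400 nM to 3000 nM.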

Compound 4, half-maximal inhibitory concentration: 300 nM
Compound 4: the middle estimate sits 3.3-fold (0.52 log units) above what was measured; the measured number lies below the stated range.
By their numbers in this assay, from the lowest: compound 4; then compounds 1 and 3 (each within the scatter of the next); then compound 2.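

At the sulfonyl sulfur, 4-methoxyphenyl brings the first downward shift beyond the scatter in this assay, with a 3.3-fold lower number from compound 3 to compound 4 (0.52 log units; beyond the scatter) and a 3.3-fold lower number from compound 1 to compound 4 (0.52 log units; beyond the scatter). Methoxy in place of carboxy on an aromatic carbon gives a 17-fold lower number from compound 2 to compound 4 (1.22 log units; beyond the scatter), the largest step among these compounds. No available evidence accounts for these steps.

From the compounds shown here alone, what an amine or a longer ether chain in place of the methoxy would give remains open. Also open, going by these compounds, is whether a 4-methoxybenzyl group on the sulfonyl sulfur would keep the lower number.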